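Swapping propylcarbonyl for acetyl in compound 3

A few compounds are considered here, and "the series" means these few. Any claim that something is new, unique, unknown or untested is made for them only; others in the source may bear on it.

- compound 1 `COc1cc(/C=C/COC(C)=O)ccc1OC(C)=O` at 360 nM
- compound 2 `CCCC(=O)OC/C=C/c1ccc(OC(=O)CCC)c(OC)c1` at 7850 nM

Both numbers come from a functional assay on SW-620 cells (Homo sapiens) for antiproliferative activity, read by sulforhodamine B assay, with a stated time of 72 h (on this read-out higher numbers stand for weaker inhibition and lower numbers for stronger inhibition), and compound 2 holds the higher of the two, which makes it the weaker inhibitor. Its gap to compound 1 lies beyond the usual scatter of repeat measurements.

Compound 3 `CCCC(=O)Oc1ccc(/C=C/COC(C)=O)cc1OC` has not been measured yet. It differs from compound 2 by a single edit, hydrogen in place of ethyl on a saturated chain carbon bound to a carbonyl carbon on a saturated chain carbon bound to a carbonyl carbon, and this turns a propylcarbonyl into an acetyl. Going by the values given here, no measured pair shows this edit on its own, so there is no measured step to carry over. Among the compounds with values here, the only guide is the span of two values. With compound 1 at 360 nM as the sole lower reference, a move down from compound 2 is expected, landing inside that span in this assay rather than beyond it. The expected change is a 4.6-fold lower number from compound 2 to compound 3 (0.66 log units; beyond the scatter) as an estimate resting on very little data. Compound 3 is estimated at 1700 nM with a likely range of 400 nM to 7000 nM on current evidence.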

Compound 3, half-maximal inhibitory concentration: 7590 nM
Beside the measured number, compound 3's estimate is 4.5-fold (0.65 log units) below it, and the stated range ends below it.
By their numbers in this assay, from the lowest: compound 1; then compounds 3 and 2 (each within the scatter of the next).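

Compound 2 carries two propylcarbonyl groups, and in this assay exchanging one of them for acetyl gives a 1.0-fold lower number from compound 2 to compound 3 (0.01 log units; within the scatter), so at this place the shorter group and the longer one cannot be told apart. The other place behaves differently: with acetyl held constant at the first place, ethyl in place of hydrogen on the remaining acetyl gives a 21-fold higher number from compound 1 to compound 3 (1.32 log units; beyond the scatter), a large loss of inhibition from one small edit. The two edits look alike on paper but are not interchangeable on this core, as the length of the group counts at one place and shows no measurable effect at the other, at least for acetyl and propylcarbonyl.

Still open, from the compounds shown here alone, is whether a longer chain such as hexyl, or an amine or a carboxylic acid in place of the acetyl, would keep or lose inhibition at either place. The strong end of the series also rests on compound 1 alone, so it is unclear how much room the place sensitive to this edit allows.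

Nothing shown here explains why the two places differ.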